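Chloro in place of fluoro: a small change expected

The source may hold more compounds than are shown below. What is called first, only, known or untested is meant among the compounds shown, and "the series" means these compounds.

Measured in an assay on 1321N1 cells for antagonist activity at P2Y purinoceptor 6 (Homo sapiens), read by FLIPR and calcium flux; a higher number here means a weaker inhibitor, a lower number a stronger inhibitor:

Compound 1 `O=[N+]([O-])C1=Cc2cc(C#Cc3ccc(F)cc3)ccc2OC1C(F)(F)F`: 8860 nM
Compound 2 `CC[Si](C#Cc1cccc2c1C=C([N+](=O)[O-])C(C(F)(F)F)O2)(CC)CC`: 4770 nM
Compound 3 `CC[Si](C#Cc1cccc2c1OC(C(F)(F)F)C([N+](=O)[O-])=C2)(CC)CC`: 461 nM

Among these three numbers, compound 1 gives the highest. Compound 2 sits close to it, within the scatter of the measurement. Compound 3 gives a far lower number, a gap well beyond the scatter.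

Compound 4 `O=[N+]([O-])C1=Cc2cc(C#Cc3ccc(Cl)cc3)ccc2OC1C(F)(F)F` differs from compound 1 in one place: chloro in place of fluoro on an aromatic carbon. Within the data shown here, no pair of measured compounds shows this same change, so there is no measured step to set against it. Resting on the change alone, the step from compound 1 to compound 4 is expected to be small, a 1.4-fold lower number from compound 1 to compound 4 (0.13 log units; within the scatter), at most a slight move toward a lower number and quite possibly none beyond the scatter. Compound 4 is therefore estimated at 6500 nM in this assay, with a range from 2200 nM to 19000 nM.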

Compound 4, half-maximal inhibitory concentration: 5350 nM
Beside the measured number, compound 4's estimate is 1.2-fold (0.08 log units) above it, within the range that was stated.
By their numbers in this assay, from the lowest: compound 3; then compounds 2, 4 and 1 (each within the scatter of the next).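

In this assay the swap of 4-fluorophenyl to 4-chlorophenyl gives a 1.7-fold lower number from compound 1 to compound 4 (0.22 log units; within the scatter) and so the two halogens read alike at this position, para to a large group. Among these compounds, this is the first pair here that differs in one place, which makes it the first direct reading of this position on the shared core. No measurement shown here accounts for the result. Going by these compounds, whether an amine, a methoxy group or a carboxylic acid at this same position would also read alike stays open. So does whether this swap would read the same on the other compounds.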